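Aromatic nitrogen substituent: isopropyl to butyl from compound 3

The source may report more compounds than this note shows. Statements on the series, on what has been measured and on what is new or still open speak of the compounds shown alone.

Compound 3 `COc1ccc(NC(=O)C(=O)c2cn(C(C)C)c3ccccc23)cn1` gives 85 nM in a functional assay on FaDu cells (Homo sapiens) for cytotoxicity, read by MTT assay, with a stated time of 72 h (on this read-out lower numbers stand for higher toxicity in this test and higher numbers for lower toxicity in this test), the lowest of the numbers shown. Compound 2 `COc1ccc(NC(=O)C(=O)c2cn(C(C)C)c3ccccc23)nn1` gives 2270 nM, and the step of a 27-fold lower number from compound 2 to compound 3 (1.43 log units; beyond the scatter) is 6-methoxypyridin-3-yl in place of 6-methoxypyridazin-3-yl on an amide-type nitrogen. Compound 1 `COc1ccc2c(c1)c(C(=O)C(=O)Nc1ccc(OC)nc1)cn2C(C)C` gives only a limit of > 10000 nM (the limit of > 10000 nM in this assay, at which 1 of the 3 values shown sits). The step of an at least 110-fold lower number from compound 1 to compound 3 (2.07 log units; beyond the scatter) is hydrogen in place of methoxy on an aromatic carbon. Compound 4 `CCCCn1cc(C(=O)C(=O)Nc2ccc(OC)nc2)c2ccccc21` differs from compound 3 by butyl in place of isopropyl on an aromatic nitrogen. Among the compounds with values here, neither measured step touches the substituent on the aromatic nitrogen, so no measured step bears directly on this change, and no step beyond the scatter is expected. The step from compound 3 to compound 4 is estimated as a 1.2-fold higher number from compound 3 to compound 4 (0.07 log units; within the scatter). Compound 4 is expected to give 100 nM, within 30 nM to 400 nM.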

Compound 4, concentration lethal to 50% of the cells: 18 nM
Compound 4: the middle estimate sits 5.6-fold (0.74 log units) above what was measured; the measured number lies below the stated range.
By their numbers in this assay, from the lowest: compound 4; then compound 3; then compound 2. At a limit, above all of these: compound 1.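

The aromatic nitrogen substituent proves to be a position that moves this read-out, with a 4.7-fold lower number from compound 3 to compound 4 (0.67 log units; beyond the scatter). The earlier steps shown here changed only a methoxy group on an aromatic carbon and the group on the amide-type nitrogen, and both were large, while this one is modest. No measurement shown gives a cause for this step.

With only isopropyl and butyl at this position, no dependence on chain length can be drawn. Within the data shown here, open are a longer chain such as hexyl, a benzyl group or a chain ending in an amine, and whether the earlier steps hold with butyl in place.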